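Nitrophenylhydrazone hydrazides: 4-methoxyphenyl amide variant

A few compounds are considered here, and "the series" means these few. Any claim that something is new, unique, unknown or untested is made for them only; others in the source may bear on it.

Measured so far in a functional assay on cells (Splenocyte, Mus musculus, strain BALB/c) for inhibition, read by scintillation counting and thymidine incorporation, with a stated time of 72 h; on this read-out lower numbers stand for stronger inhibition and higher numbers for weaker inhibition:
- compound 1, `CC(/C=N/Nc1ccc([N+](=O)[O-])cc1)=N\NC(=O)c1ccccc1O`: compound 1 gives 1640 nM
- compound 2, `CC(/C=N/Nc1ccc([N+](=O)[O-])cc1)=N\NC(=O)c1cccc(C)c1`: compound 2 gives > 12000 nM

The value of compound 2 in this assay is a limit, not a number; it is the same limit described by the limit of > 12000 nM in this assay, at which 1 of the 2 values shown sits. Among the measured compounds shown here, compound 2 therefore stands at the weak end of the pair, and the only measured step, an at least 7.3-fold higher number from compound 1 to compound 2 (0.86 log units; beyond the scatter), runs toward it.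

Compound 3, `COc1ccc(C(=O)N/N=C(C)/C=N/Nc2ccc([N+](=O)[O-])cc2)cc1`, differs from compound 2 by 4-methoxyphenyl in place of 3-methylphenyl on a carbonyl carbon. For the measured compounds named here, no measured step covers this exchange: the one step on record replaces a 2-hydroxyphenyl with a 3-methylphenyl, whereas here a 3-methylphenyl is exchanged for a 4-methoxyphenyl, so its size cannot be carried over. Since compound 2 is known only as a limit, the step of an at least 1.2-fold lower number from compound 2 to compound 3 (0.07 log units; that floor lies within the scatter) is expected to be small and may not be resolved at all. In this assay compound 3 is estimated at 10000 nM, within 3000 nM to 30000 nM, with a fair chance that only a limit is reported.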

Compound 3, half-maximal inhibitory concentration: > 12000 nM
Compound 3: a limit, no number; the forecaster's own chance of this, stated with the estimate: 55%; middle value at least 1.2-fold (0.07 log units) away from the limit.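

In this assay, moving from 2-hydroxyphenyl to 4-methoxyphenyl on the carbonyl carbon gives an at least 7.3-fold higher number from compound 1 to compound 3 (0.86 log units; beyond the scatter), so a second, different replacement of that group also ends beyond the scatter. Compound 3, like compound 2, is known only as a limit, not a number: the limit of > 12000 nM in this assay, at which 2 of the 3 values shown sit.

The step between compound 2 and compound 3 cannot be read, so 3-methylphenyl and 4-methoxyphenyl cannot be ranked, and among the three groups shown at this place only the 2-hydroxyphenyl of compound 1 gives a measured number.

Still open, going by these compounds, is what an unsubstituted phenyl or a 2-methoxyphenyl on this carbonyl carbon would give, and with it whether the hydroxyl of compound 1 is what keeps a number readable. On these data alone, how far compound 2 and compound 3 lie past their limit also remains open.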